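Adding an ethyl group to the ring amide nitrogen of compound 2

The source may hold more compounds than are shown below. What is called first, only, known or untested is meant among the compounds shown, and "the series" means these compounds.

In a functional assay on MDA-MB-231 cells (Homo sapiens) for inhibition, read by MTT assay, with a stated time of 48 h (a lower number here means a stronger inhibitor, a higher number a weaker inhibitor), compound 2 `CN1CCN(c2ccc(Nc3ncc4c(n3)N(C3CCCC3)CC(=O)N4)cc2)CC1` gives 26100 nM, the higher of the two numbers reported. Its nearest neighbour, compound 3 `CC1CCN(c2ccc(Nc3ncc4c(n3)N(C3CCCC3)CC(=O)N4)cc2)CC1`, gives 22700 nM in this assay, and a 1.1-fold lower number from compound 2 to compound 3 (0.06 log units; within the scatter) lies within the scatter, so the two show no difference. Compound 1 `CCN1C(=O)CN(C2CCCC2)c2nc(Nc3ccc(OC)cc3)ncc21` is reported in this assay only as a limit, > 30000 nM, not as a number (the limit of > 30000 nM in this assay, at which 1 of the 3 values shown sits).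

Compound 4 `CCN1C(=O)CN(C2CCCC2)c2nc(Nc3ccc(N4CCN(C)CC4)cc3)ncc21` differs from compound 2 by ethyl in place of hydrogen on an amide-type nitrogen in a ring. Going by the values given here, no measured pair differs in this place alone: the only measured step, from compound 2 to compound 3, changes the group on the aromatic carbon instead, and compound 1 carries the ethyl group together with a different aryl substituent, so it does not isolate the change. The expected change from compound 2 to compound 4 is therefore a 1.1-fold higher number from compound 2 to compound 4 (0.06 log units; within the scatter), essentially none beyond the scatter, given that compound 1 shows only the limit > 30000 nM. Compound 4 is thus expected to give 30000 nM in this assay, in the range 10000 nM to 100000 nM, with a fair chance that only a limit is reported.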

Compound 4, half-maximal inhibitory concentration: 26200 nM
Beside the measured number, compound 4's estimate is 1.1-fold (0.06 log units) above it; the measured number falls inside the stated range.
By their numbers in this assay, from the lowest: compounds 3, 2 and 4 (each within the scatter of the next). At a limit, above all of these: compound 1.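

In this assay, going by these compounds alone, ethyl in place of hydrogen on the amide-type nitrogen in a ring gives a 1.0-fold higher number from compound 2 to compound 4 (0.00 log units; within the scatter): this is the first view of this position changed alone, and with the 4-methylpiperazin-1-yl group held in place the two compounds show no difference. Compound 1 is reported only as a limit: the limit of > 30000 nM in this assay, at which 1 of the 4 values shown sits. The step of an at least 1.1-fold lower number from compound 1 to compound 4 (0.05 log units; that floor lies within the scatter) therefore gives only a floor, and it does not settle whether 4-methylpiperazin-1-yl and methoxy on the aromatic carbon differ.

The compounds shown leave open whether a longer chain on this nitrogen, or a chain ending in an amine or a carboxylic acid, would match ethyl. They also leave open whether ethyl would show a difference alongside the 4-methylpiperidin-1-yl group of compound 3.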